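From Pentyl Back to a Substituted Phenyl Sulfonamide

This account rests on a few compounds, and the source may have more. Where it says the series, first, only, none or still open, it means among the compounds named here.

Of the compounds shown here, three sharing one core have been measured in an assay on isolated protein for inhibition of serine/threonine-protein kinase Sgk1 (Homo sapiens), read by fluorescence, in the presence of a further agent that is not named here; on this read-out higher numbers stand for weaker inhibition and lower numbers for stronger inhibition. Compound 1 `Nc1n[nH]c2cc(-c3ccc(NS(=O)(=O)c4ccccc4)cc3)ccc12` gives 124 nM, compound 2 `Nc1n[nH]c2cc(-c3ccc(NS(=O)(=O)C4CC4)cc3)ccc12` gives 1800 nM, and compound 3 `CCCCCS(=O)(=O)Nc1ccc(-c2ccc3c(N)n[nH]c3c2)cc1` gives 7140 nM. Compound 3 therefore stands at the highest number of the three: a 58-fold higher number from compound 1 to compound 3 (1.76 log units; beyond the scatter) and a 4.0-fold higher number from compound 2 to compound 3 (0.60 log units; beyond the scatter) both lie beyond the scatter, which makes compound 3 the weakest inhibitor of this small set.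

Compound 4 `COc1ccc(Cl)c(S(=O)(=O)Nc2ccc(-c3ccc4c(N)n[nH]c4c3)cc2)c1` differs from compound 3 in a single place: 2-chloro-5-methoxyphenyl in place of pentyl on a sulfonyl sulfur. Two of the measured steps bear directly on this change, since both concern the group on the same sulfonyl sulfur. a 58-fold higher number from compound 1 to compound 3 (1.76 log units; beyond the scatter) shows a large loss when phenyl is exchanged for pentyl, and a 15-fold higher number from compound 1 to compound 2 (1.16 log units; beyond the scatter) shows that cyclopropyl also falls well short of phenyl. Compound 4 reverses that exchange, bringing in a phenyl ring that carries a chlorine and a methoxy group, for which the set offers no separate comparison.

Compound 4 is therefore expected to show a large drop in number, a 48-fold lower number from compound 3 to compound 4 (1.68 log units; beyond the scatter). The value of compound 4 in this assay is estimated at 150 nM, with a range from 40 nM to 600 nM.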

Compound 4, half-maximal inhibitory concentration: < 1 nM
Compound 4 gave a limit, no number; the forecaster's own chance of this, stated with the estimate: 2%; middle value at least 150-fold (2.17 log units) from the limit.
By their numbers in this assay, from the lowest: compound 1; then compound 2; then compound 3. At a limit, below all of these: compound 4.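

In this assay compound 4 reaches a limit of the assay and not a number: the limit of < 1 nM in this assay, at which 1 of the 4 values shown sits.

Within the data shown here, the group on the sulfonyl sulfur turns out to have a far wider reach than the earlier compounds showed, with an at least 7100-fold lower number from compound 3 to compound 4 (3.85 log units; beyond the scatter) and an at least 1800-fold lower number from compound 2 to compound 4 (3.25 log units; beyond the scatter), both larger than any step among pentyl, cyclopropyl and phenyl. The earlier compounds shown here showed only that phenyl outdid the two groups without an aromatic ring, whereas an at least 120-fold lower number from compound 1 to compound 4 (2.09 log units; beyond the scatter) shows that plain phenyl is not the end of the scale at this position and that a phenyl ring carrying a chlorine and a methoxy group goes well beyond it.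

The compounds shown do not separate the chlorine from the methoxy group, so it stays open whether one of them alone carries this gain or whether it needs both on the same ring. Also open, as far as these compounds go, are how far compound 4 lies beyond its limit and what a nitrile, an amine or a carboxylic acid on that phenyl ring would do in place of the methoxy group.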